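A Fluoro for Methoxy Swap on the Pendant Phenyl Ring

The source may report more compounds than this note shows. Statements on the series, on what has been measured and on what is new or still open speak of the compounds shown alone.

Compound 1 `CC(=O)c1ccc(-c2cn3ccnc3c(-c3ccc4ncn(C5CCCCC5)c4c3)n2)cc1`: 15.9%
Compound 2 `Brc1ccc(-c2cn3ccnc3c(-c3ccc4ncn(C5CCCCC5)c4c3)n2)cc1`: 31.2%
Compound 3 `COc1ccccc1-c1cn2ccnc2c(-c2ccc3ncn(C4CCCCC4)c3c2)n1`: 28.3%

In a functional assay on HCT-116 cells (Homo sapiens) for inhibition, read by sulforhodamine B assay, with a stated time of 48 h, tested at 10 uM (a lower number here means less inhibition, a higher number more inhibition at the concentration tested (going by the name of the read-out)), compound 3 stands second highest of the three numbers. The step of a number 2.9 percentage points lower from compound 2 to compound 3 (within the scatter) lies within the scatter, so no order can be read between these two, whereas the step of a number 12.4 percentage points higher from compound 1 to compound 3 (beyond the scatter) is beyond the scatter and modest. Compound 4 `Fc1ccccc1-c1cn2ccnc2c(-c2ccc3ncn(C4CCCCC4)c3c2)n1` differs from compound 3 by fluoro in place of methoxy on an aromatic carbon. Among the compounds with values here, no measured step exchanges these two groups; the steps that do bear on the pendant ring, a number 15.3 percentage points higher from compound 1 to compound 2 (beyond the scatter) and a number 12.4 percentage points higher from compound 1 to compound 3 (beyond the scatter), are modest, and a number 2.9 percentage points lower from compound 2 to compound 3 (within the scatter) is within the scatter. A step of a number 2.3 percentage points lower from compound 3 to compound 4 (within the scatter) is therefore expected, none beyond the scatter. Compound 4 is estimated at 26%, with a range from 12% to 40%.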

Compound 4, a percentage reported as inhibition, at one concentration (the size of the read-out at that concentration, not a potency): 25.8%
Compound 4: the middle estimate sits 0.2 percentage points above what was measured; the measured number falls inside the stated range.
By their numbers in this assay, from the lowest: compounds 1, 4, 3 and 2 (each within the scatter of the next, the first and the last beyond it).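

In this assay, putting fluoro in place of methoxy ortho to a large group gives a step within the scatter (a number 2.5 percentage points lower from compound 3 to compound 4 (within the scatter)), so this position accepts the change from methoxy to the single fluorine atom without a readable shift. The other new steps (a number 5.4 percentage points lower from compound 2 to compound 4 (within the scatter) and a number 9.9 percentage points higher from compound 1 to compound 4 (within the scatter)) also lie within the scatter, so compound 4 cannot be ordered against any of the other three, although compound 3 stands apart from compound 1. Nothing at hand explains these numbers.

From the compounds shown here alone, whether an amine, a carboxylic acid or a longer chain such as butoxy at this position would move the number beyond the scatter stays open. Potency also stays open, as each number comes from a single concentration.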